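Nitro in place of hydroxy: compound 3 to compound 4

The source may report more compounds than this note shows. Statements on the series, on what has been measured and on what is new or still open speak of the compounds shown alone.

In a functional assay on Bel-7402 cells (Homo sapiens) for antiproliferative activity, read by MTT assay, with a stated time of 48 h (on this read-out higher numbers stand for weaker inhibition of growth and lower numbers for stronger inhibition of growth), compound 1 (`COc1ccc(/C=C2\Cc3c(cc(OC)c(OC)c3OC)C2=O)cc1[N+](=O)[O-]`) gives 950 nM, a measured number. Compound 2 (`COc1cc2c(c(OC)c1OC)C/C(=C\c1cc(OC)c(OC)c(OC)c1OC)C2=O`) reads > 10000 nM, which is a limit of this assay. Compound 3 (`COc1ccc(/C=C2\Cc3cc(OC)c(OC)c(OC)c3C2=O)cc1O`) reads > 10000 nM, also a limit. Compound 3 thus stands at the limit of > 10000 nM in this assay, at which 2 of the 3 values shown sit, with no number to start from.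

Compound 4 (`COc1ccc(/C=C2\Cc3cc(OC)c(OC)c(OC)c3C2=O)cc1[N+](=O)[O-]`) is not yet measured. It carries nitro in place of hydroxy on an aromatic carbon, ortho to a methoxy group: nitro in place of hydroxy on an aromatic carbon. Within the data shown here, no step between measured compounds gauges this change. Among the measured compounds shown here, the only compound with a number, compound 1, also carries a nitro group and gives 950 nM, and that is the sole ground for expecting stronger inhibition of growth in this assay. The expected move is an at least 3.3-fold lower number from compound 3 to compound 4 (0.52 log units; beyond the scatter), and a reading at the limit remains possible. For compound 4 the estimated value is 3000 nM, with an expected range of 300 nM to 20000 nM.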

Compound 4, concentration for 50% growth inhibition: > 10000 nM
Compound 4: no number, only a limit; the forecaster's own chance of this, stated with the estimate: 35%; middle value at least 3.3-fold (0.52 log units) from the limit.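

Compound 3 and compound 4 both stand at a limit, not a number, in this assay, and the step between them cannot be read: the limit of > 10000 nM in this assay, at which 3 of the 4 values shown sit.

Still open is the size of the change from hydroxy to nitro on an aromatic carbon: no pair of compounds shown carries a number on both sides of it.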